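The source may hold more compounds than are shown below. What is called first, only, known or untested is meant among the compounds shown, and "the series" means these compounds.

Among the measured compounds shown here, compound 1 `CCOc1ccccc1N1CCN(CCCNc2ncccc2C(=O)N(C)C)CC1` is one of two compounds measured in a functional assay for antagonist activity at Alpha-1A adrenergic receptor (Oryctolagus cuniculus) (on this read-out higher numbers stand for weaker binding and lower numbers for tighter binding), where compound 1 gives 0.501 nM, the highest of the two numbers. For the measured compounds named here, the other, compound 2 `CN(C)C(=O)c1cccnc1NCCCN1CCN(c2ccccc2OCC(F)(F)F)CC1`, gives 0.1 nM in this assay, and the only measured step, a 5.0-fold lower number from compound 1 to compound 2 (0.70 log units; beyond the scatter), arises from trifluoromethyl in place of methyl on a saturated chain carbon bound to an oxygen on an aromatic ring. Compound 3 `COc1cc(O)ccc1N1CCN(CCCNc2ncccc2C(=O)N(C)C)CC1` differs from compound 1 elsewhere: 4-hydroxy-2-methoxyphenyl in place of 2-ethoxyphenyl on an amine nitrogen in a ring. Going by the values given here, no measured step touches this group on the amine nitrogen in a ring, so the step from compound 1 to compound 2 offers no direct guide to direction or size here; it shows only that the aromatic ether region of the shared core admits change without loss. With nothing pointing either way, compound 3 is expected to stay close to compound 1, the expected step being a 1.6-fold higher number from compound 1 to compound 3 (0.20 log units; within the scatter). Compound 3 is therefore estimated at 0.8 nM, with a range from 0.25 nM to 2.5 nM.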

Compound 3, dissociation constant: 12.6 nM
For compound 3 the middle estimate is 16-fold (1.20 log units) below the measured one, outside the stated range (above it).
By their numbers in this assay, from the lowest: compound 2; then compound 1; then compound 3.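

Among the compounds shown here, the swap of 2-ethoxyphenyl for 4-hydroxy-2-methoxyphenyl on the amine nitrogen in a ring gives, in this assay, a 25-fold higher number from compound 1 to compound 3 (1.40 log units; beyond the scatter) and so is the first measured change to cost binding, showing that this position does not accept every substitution. The two groups have the same heavy-atom count, so the large step arises without any change in that count, while the entering group carries a hydrogen-bond donor that the leaving group lacks. Nothing available here explains the step.

As far as these compounds go, the change alters two things at once, the added hydroxy and methoxy in place of ethoxy, and which of them carries the step stays open. A 2-methoxyphenyl or a 4-hydroxy-2-ethoxyphenyl group on the same nitrogen would separate the two.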